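The compounds below may be only part of what the source reports. "The series", "measured", "known", "first", "only" and "open" are said of these compounds alone.

Working notes on the series. Going by the values given here, compound 2 `Cc1cccc(NC(=O)Nc2cc(Oc3ccc4nc(NC(=O)C5CC5)sc4c3)ccc2F)c1` stands lowest of the two numbers so far in an assay for binding affinity to receptor-interacting serine/threonine-protein kinase 3 (Homo sapiens), read by KINOMEscan and polymerase chain reaction, with a stated time of 1 h; on this read-out higher numbers stand for weaker binding and lower numbers for tighter binding: in that assay compound 2 gives 93 nM. Among the compounds with values here, its nearest neighbour is compound 1 `O=C(CCc1cccc(C(F)(F)F)c1)Nc1cc(Oc2ccc3nc(NC(=O)C4CC4)sc3c2)ccc1F`, which in this assay gives 790 nM; the only measured step, an 8.5-fold lower number from compound 1 to compound 2 (0.93 log units; beyond the scatter), swaps the whole group on the carbonyl carbon and says nothing about substitution on the 3-methylphenyl ring itself.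

Compound 3 `CC(=O)c1cccc(NC(=O)Nc2cc(Oc3ccc4nc(NC(=O)C5CC5)sc4c3)ccc2F)c1` differs from compound 2 by acetyl in place of methyl on an aromatic carbon. Within the data shown here, no measured step bears on this change; the step of an 8.5-fold lower number from compound 1 to compound 2 (0.93 log units; beyond the scatter) alters a different part of the molecule and gives no direction for an acetyl in place of methyl. With nothing to point either way, the expectation for this assay is a step of a 1.2-fold higher number from compound 2 to compound 3 (0.07 log units; within the scatter) that stays within the usual scatter, in either direction. The estimate for compound 3 in this assay is therefore 110 nM, with a range from 30 nM to 400 nM.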

Compound 3, dissociation constant: 53 nM
Beside the measured number, compound 3's estimate is 2.1-fold (0.32 log units) above it, within the range that was stated.
By their numbers in this assay, from the lowest: compounds 3 and 2 (each within the scatter of the next); then compound 1.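

On this aromatic carbon, meta to a large group, acetyl in place of methyl gives a 1.8-fold lower number from compound 2 to compound 3 (0.24 log units; within the scatter) in this assay, so two more heavy atoms and one hydrogen-bond acceptor leave the reading within the scatter. The second comparison, a 15-fold lower number from compound 1 to compound 3 (1.17 log units; beyond the scatter), shows that the gap beyond the scatter first seen with compound 2 also appears with the (3-acetylphenyl)amino group on the carbonyl carbon. Nothing on hand gives a reason for either step.

As far as these compounds go, whether an amine or a carboxylic acid on this same carbon would also stay within the scatter remains open, as does the effect of moving acetyl to another carbon of the ring. Compound 1 differs from compound 2 and compound 3 in both chain and ring substituent, so the share of trifluoromethyl in those steps cannot be separated.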